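Changing the aryl amine once more on a shared core

A few compounds are considered here, and "the series" means these few. Any claim that something is new, unique, unknown or untested is made for them only; others in the source may bear on it.

Compound 2 `CCS(=O)(=O)Nc1cc(-c2ccc3ncnc(Nc4ccc(OC(F)(F)F)cc4)c3c2)cnc1OC` gives the higher of the two numbers in a functional assay on SNU-638 cells (Homo sapiens) for cytotoxicity, read by sulforhodamine B assay, with a stated time of 72 h (a lower number here means a stronger inhibitor, a higher number a weaker inhibitor), at 22400 nM. Among the compounds with values here, its only measured neighbour, compound 1 `CCS(=O)(=O)Nc1cc(-c2ccc3ncnc(Nc4ccc(F)cc4F)c3c2)cnc1OC`, gives 2050 nM, and the single measured change at this position, an 11-fold higher number from compound 1 to compound 2 (1.04 log units; beyond the scatter), shows that the group on this nitrogen can shift the number a great deal. Compound 3 `CCS(=O)(=O)Nc1cc(-c2ccc3ncnc(Nc4ccc(OC)c(OC)c4)c3c2)cnc1OC` alters the same position again: 3,4-dimethoxyphenyl in place of 4-(trifluoromethoxy)phenyl on a nitrogen on an aromatic ring. Within the data shown here, no measured step covers this exact swap, so direction and size are uncertain. Compound 3 is therefore expected near 10000 nM, between 2000 nM and 50000 nM. That amounts to an expected 2.2-fold lower number from compound 2 to compound 3 (0.35 log units; beyond the scatter).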

Compound 3, half-maximal inhibitory concentration: 1680 nM
Beside the measured number, compound 3's estimate is 6.0-fold (0.77 log units) above it; measured number below the stated range.
By their numbers in this assay, from the lowest: compounds 3 and 1 (each within the scatter of the next); then compound 2.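

In this assay the large step, a 13-fold lower number from compound 2 to compound 3 (1.12 log units; beyond the scatter), shows that the high number of compound 2 is not shared by every substituted phenyl on this nitrogen. The second step, a 1.2-fold lower number from compound 1 to compound 3 (0.09 log units; within the scatter), lies within the scatter, so 3,4-dimethoxyphenyl and 2,4-difluorophenyl cannot be told apart here, and compound 2 stands alone among the three. Fluorine alone does not decide the number, since compound 1 and compound 2 both carry it. Nothing measured here bears on the reason for these differences. Still open, going by these compounds, is how a single methoxy group, or an amine or carboxylic acid on this phenyl ring, would compare.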